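This account rests on a few compounds, and the source may have more. Where it says the series, first, only, none or still open, it means among the compounds named here.

Measured so far:
compound 1 `CC(C)c1ccc(C2CN(C)Cc3c(N)cccc32)cc1` — about 65 mg/kg
compound 2 `CCNC(=O)Nc1cccc2c1CN(C)CC2c1ccccc1` — > 80 mg/kg

In a functional assay on the whole organism for inhibition of sodium-dependent dopamine transporter (Mus musculus) (a lower number here means that less compound is needed, a higher number that more compound is needed for the effect), compound 1 gives about 65 mg/kg. For compound 2 the number known in this assay is only a limit, > 80 mg/kg; compound 2 sits at the limit of > 80 mg/kg in this assay, at which 1 of the 2 values shown sits. Compound 3 `CCCNC(=O)Nc1cccc2c1CN(C)CC2c1ccccc1` differs from compound 2 by methyl in place of hydrogen on a saturated chain carbon, two bonds along the chain from an amide-type nitrogen. Within the data shown here, no measured step covers this kind of change, so compound 3 is expected to stay close to compound 2, with a step that the limit leaves unreadable from compound 2 to compound 3 that is not expected to go beyond the scatter in either direction. Compound 3 is estimated at 95 mg/kg in this assay, within 50 mg/kg to 180 mg/kg, and it may well again come back only as a limit.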

Compound 3, dose for half-maximal effect: > 120 mg/kg
Compound 3: a limit, no number; the forecaster's own chance of this, stated with the estimate: 65%; middle value at least 1.2-fold (0.10 log units) from the limit.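

Compound 2 and compound 3 both return only limits in this assay, and the step between them cannot be read. The compounds shown leave open whether ethylamino to propylamino changes the dose needed at all.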